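Swapping Bromine for Methyl on the Sulfonyl-Bound Ring

A few compounds are considered here, and "the series" means these few. Any claim that something is new, unique, unknown or untested is made for them only; others in the source may bear on it.

Compound 1, `COc1ccc(-c2cc(=O)c3c(OC)cc(OC)cc3n2S(=O)(=O)c2cccc([N+](=O)[O-])c2)cc1`, gives in a functional assay on SUP-B15 cells (Homo sapiens) for antiproliferative activity, with a stated time of 72 h (a lower number here means that less compound is needed, a higher number that more compound is needed for the effect), a value that is a limit of the assay rather than a number, > 39600 nM.
Compound 2, `COc1ccc(-c2cc(=O)c3c(OC)cc(OC)cc3n2S(=O)(=O)c2ccc(Br)cc2)cc1`, gives in this assay a value of 63800 nM.

Among the measured compounds shown here, compound 2 is thus the only compound of the pair with a measured number in this assay; the other value shown is a limit (the limit of > 39600 nM in this assay, at which 1 of the 2 values shown sits). For the measured compounds named here, the one measured step, a step that the limit leaves unreadable from compound 1 to compound 2, has no readable size, since it runs from a limit to a number.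

Compound 3, `COc1ccc(-c2cc(=O)c3c(OC)cc(OC)cc3n2S(=O)(=O)c2ccc(C)cc2)cc1`, differs from compound 2 by methyl in place of bromo on an aromatic carbon. Going by the values given here, no measured step bears on this exchange: the step from compound 1 to compound 2 concerns another substituent on the same sulfonyl-bound ring, and its size cannot be read. The expectation for compound 3 therefore rests on compound 2 alone, with no ground for a shift in either direction beyond the scatter. Compound 3 is expected at 65000 nM, in a range from 25000 nM to 180000 nM. The step from compound 2 to compound 3 is expected to be a 1.0-fold higher number from compound 2 to compound 3 (0.01 log units; within the scatter), within the scatter.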

Compound 3, half-maximal effective concentration: > 44800 nM
Compound 3 gave a limit, no number; the forecaster's own chance of this, stated with the estimate: 45%; the middle value lies beyond the limit too.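

Compound 3 gives a limit of the assay and not a number, > 44800 nM. Compound 1 also stands at a limit, so neither step from compound 3 to compound 1 or compound 2 can be read. The compounds shown leave open how the 4-methylphenyl, 4-bromophenyl and 3-nitrophenyl groups on the sulfonyl sulfur truly compare in this assay.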